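Methyl to chloro swap: cytotoxicity expectation for compound 3

The source may report more compounds than this note shows. Statements on the series, on what has been measured and on what is new or still open speak of the compounds shown alone.

Compound 1 `COc1ccc2c(=O)c(/C=C/C(=O)Nc3ccccc3)coc2c1` and compound 2 `COc1ccc2c(=O)c(/C=C/C(=O)Nc3ccccc3C)coc2c1` share the same core and differ only by a methyl on an aromatic carbon. Among the compounds with values here, in an ADME assay on HepG2 2.2.15 cells (Homo sapiens) for cytotoxicity, read by MTT assay, with stated times of 48 h and 9 days (on this read-out lower numbers stand for higher toxicity in this test and higher numbers for lower toxicity in this test), compound 1 gives 523000 nM, and compound 2 gives 59700 nM; the step of an 8.8-fold lower number from compound 1 to compound 2 (0.94 log units; beyond the scatter) is the only measured step in the set. Compound 2 therefore stands lowest of the two numbers, with compound 1 the nearest neighbour at a higher number. Compound 3 `COc1ccc2c(=O)c(/C=C/C(=O)Nc3ccccc3Cl)coc2c1` differs from compound 2 by chloro in place of methyl on an aromatic carbon. Within the data shown here, no measured step exchanges chloro for methyl, so the hydrogen-to-methyl step bears on it only as a sign that a single group on this aromatic carbon can shift the number beyond the scatter. Without a direct precedent, the expected step of a 1.2-fold lower number from compound 2 to compound 3 (0.08 log units; within the scatter) is within the scatter, in no settled direction. Compound 3 is estimated at 50000 nM, ranging from 15000 nM to 160000 nM.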

Compound 3, half-maximal cytotoxic concentration: 1010000 nM
The estimate for compound 3 lay 20-fold (1.31 log units) below the measured number, and the stated range ends below it.
By their numbers in this assay, from the lowest: compound 2; then compounds 1 and 3 (each within the scatter of the next).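

On this aromatic carbon, ortho to a large group, the kind of single group matters in this assay: chloro in place of methyl gives a 17-fold higher number from compound 2 to compound 3 (1.23 log units; beyond the scatter), although each group has one heavy atom. Chloro in place of hydrogen gives a 1.9-fold higher number from compound 1 to compound 3 (0.29 log units; within the scatter), so occupying this carbon does not by itself carry the shift seen in an 8.8-fold lower number from compound 1 to compound 2 (0.94 log units; beyond the scatter), and among these three compounds only compound 2, with methyl, stands apart. No measured evidence accompanies these numbers to account for the difference between methyl and chloro.

Open, as far as these compounds go, is whether the low number belongs to methyl alone or also appears with ethyl, methoxy or an amine on this carbon. Also open, from the compounds shown here alone, is whether methyl and chloro differ in the same way on other carbons of this ring.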